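The source may report more compounds than this note shows. Statements on the series, on what has been measured and on what is new or still open speak of the compounds shown alone.

Compound 1, `COc1cc2cc(C(=O)CCC3CC[N+](C)(Cc4ccccc4)CC3)sc2cc1OC`, is one of three compounds with a shared core that have been measured in a physicochemical assay for solubility; on this read-out lower numbers stand for lower solubility and higher numbers for higher solubility. Compound 1 gives 2000 ug/mL. Compound 3, `COc1cc2cc(C(=O)CCCCC3CC[N+](C)(Cc4ccccc4)CC3)sc2cc1OC`, gives 1000 ug/mL in this assay, and the gap between compound 1 and compound 3 lies within the usual scatter of repeated measurements, so the two cannot be told apart. Compound 2, `COc1cc2cc(C(=O)CC(O)C3CC[N+](C)(Cc4ccccc4)CC3)sc2cc1OC`, has several entries in this assay, 10000 ug/mL; 8000 ug/mL; 10000 ug/mL (3 entries), and the several entries of compound 2 in this assay, 10000 ug/mL; 8000 ug/mL; 10000 ug/mL (3 entries) shows how closely its repeats agree. Compound 4, `COc1cc2cc(C(=O)CCC3CC[N+](C)(Cc4ccc([N+](=O)[O-])o4)CC3)sc2cc1OC`, has not yet been measured in this assay. It differs from compound 1 in one place: 5-nitrofuran-2-yl in place of phenyl on a saturated chain carbon bound to an amine nitrogen in a ring. Going by the values given here, no measured pair of compounds shows this change, so the size of its effect is not known from the data. The step from compound 1 to compound 4 in this assay, a 1.3-fold lower number from compound 1 to compound 4 (0.12 log units; within the scatter), is expected to be small, at most a slight lowering that stays within the scatter. Compound 4 is therefore estimated to give 1500 ug/mL in this assay, with a range from 500 ug/mL to 4000 ug/mL.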

Compound 4, solubility: 600 ug/mL
The estimate for compound 4 lay 2.5-fold (0.40 log units) above the measured number; low and high end bracket the measured number.
By their numbers in this assay, from the lowest: compounds 4, 3 and 1 (each within the scatter of the next, the first and the last beyond it).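

The earlier compounds shown here all carried phenyl on a saturated chain carbon bound to an amine nitrogen in a ring, so they could not show whether this place matters for this assay. Compound 4 shows that it does: a 3.3-fold lower number from compound 1 to compound 4 (0.52 log units; beyond the scatter), even though 5-nitrofuran-2-yl has 3 hydrogen-bond acceptors and phenyl has 0. Repeat measurements can agree closely in this assay, which supports reading the step as a real difference rather than noise: the several entries of compound 2 in this assay, 10000 ug/mL; 8000 ug/mL; 10000 ug/mL (3 entries)

This single pair cannot show whether the lower number comes from the five-membered ring or from the nitro group, or whether the step would be the same with a different chain. A plain furan-2-yl group and a nitrophenyl group at this place would separate the contributions of the ring and the nitro group.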